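Acid ceramidase inhibitors: varying the aryl substituent

The source may hold more compounds than are shown below. What is called first, only, known or untested is meant among the compounds shown, and "the series" means these compounds.

Of the compounds shown here, three sharing one core have been tested in an assay on HEK293 cells for inhibition of acid ceramidase (Homo sapiens), read by fluorescence, with stated times of 10 min and 3 h; a higher number here means a weaker inhibitor, a lower number a stronger inhibitor. Compound 1 `O=C(NCCCCc1ccccc1)n1c(=O)oc2cc(C3CCOCC3)ccc21` carries an oxan-4-yl group and gives 68 nM. Compound 2 `CC(C)N1CCC(c2ccc3c(c2)oc(=O)n3C(=O)NCCCCc2ccccc2)CC1` carries a 1-isopropylpiperidin-4-yl group in its place; in this assay compound 2 gives 94 nM. Compound 3 `CN1CCN(c2ccc3c(c2)oc(=O)n3C(=O)NCCCCc2ccccc2)C(=O)C1` carries a 4-methyl-2-oxopiperazin-1-yl group; in this assay compound 3 gives 52 nM. Compound 3 has the lowest of the three numbers, yet both neighbours sit within the scatter: a 1.3-fold lower number from compound 1 to compound 3 (0.12 log units; within the scatter) and a 1.8-fold lower number from compound 2 to compound 3 (0.26 log units; within the scatter). The shift a 1.4-fold higher number from compound 1 to compound 2 (0.14 log units; within the scatter) is likewise within the scatter, so the three substituents are not distinguished by these data.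

Compound 4 `CC(C)CN1CCC(c2ccc3c(c2)oc(=O)n3C(=O)NCCCCc2ccccc2)CC1` has not yet been measured. Its change from compound 3 is 1-isobutylpiperidin-4-yl in place of 4-methyl-2-oxopiperazin-1-yl on an aromatic carbon. The step most relevant to it is the one in the opposite direction, from compound 2 to compound 3, where an isopropyl-bearing piperidine was exchanged for the piperazinone; since that step, a 1.8-fold lower number from compound 2 to compound 3 (0.26 log units; within the scatter), stayed within the scatter, compound 4, which differs from compound 2 only by isobutyl instead of isopropyl on the piperidine nitrogen, is expected to land close to compound 2 and compound 3, with a 1.7-fold higher number from compound 3 to compound 4 (0.24 log units; within the scatter) expected to be no larger than the scatter. Compound 4 is therefore estimated at 90 nM, with a range from 40 nM to 200 nM.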

Compound 4, half-maximal inhibitory concentration: 120 nM
Beside the measured number, compound 4's estimate is 1.3-fold (0.12 log units) below it; low and high end bracket the measured number.
By their numbers in this assay, from the lowest: compounds 3, 1, 2 and 4 (each within the scatter of the next, the first and the last beyond it).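

In this assay, going by these compounds alone, the exchange of 4-methyl-2-oxopiperazin-1-yl for 1-isobutylpiperidin-4-yl gives the first step at this aromatic carbon that lies beyond the scatter, though it is modest (a 2.3-fold higher number from compound 3 to compound 4 (0.36 log units; beyond the scatter)), so two groups at this position can now be told apart. That separation holds for this pair alone: isobutyl in place of isopropyl on the piperidine nitrogen gives only a 1.3-fold higher number from compound 2 to compound 4 (0.11 log units; within the scatter), and 1-isobutylpiperidin-4-yl in place of oxan-4-yl gives a 1.8-fold higher number from compound 1 to compound 4 (0.25 log units; within the scatter), so neither change distinguishes its two compounds. Within the data shown here, no supporting measurement is available to explain the one step that stands out.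

The compounds shown leave open which part of the exchange carries that step, since the ring carbonyl, the second ring nitrogen and the isobutyl chain all change together between compound 3 and compound 4. They also leave open whether a piperidine with a free amine hydrogen, or with a longer chain such as n-hexyl on its nitrogen, would remain within the scatter of compound 4 or differ from it.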